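This account rests on a few compounds, and the source may have more. Where it says the series, first, only, none or still open, it means among the compounds named here.

Compound 1 `O=C(NNc1ccccc1Cl)c1cccc(NS(=O)(=O)c2cnc(O)nc2O)c1`: 2270 nM
Compound 2 `O=C(NNc1ccccc1Cl)c1ccccc1NS(=O)(=O)c1cnc(O)nc1O`: > 20000 nM (a limit)

Within the data shown here, in a functional assay on SGC-7901 cells (Homo sapiens) for antiproliferative activity, read by MTT assay, with a stated time of 24 h (on this read-out higher numbers stand for weaker inhibition and lower numbers for stronger inhibition), compound 1 gives 2270 nM and is the only compound here with an actual number. Compound 2 reads > 20000 nM, which is a limit of the assay and not a number.

Compound 3 `O=C(NNC(=O)c1ccccc1Cl)c1cccc(NS(=O)(=O)c2cnc(O)nc2O)c1` keeps the core of compound 1 and changes one group: (2-chlorophenyl)carbonyl in place of 2-chlorophenyl on an amine nitrogen. Among the measured compounds shown here, no measured pair in this small set shows what such a change does, so the expectation rests on little. Starting from compound 1 at 2270 nM, a modest shift towards weaker inhibition in this assay is expected rather than a large one. The estimated change is a 2.2-fold higher number from compound 1 to compound 3 (0.34 log units; beyond the scatter). For compound 3 the expected value is 5000 nM, with an estimated range from 1200 nM to 18000 nM.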

Compound 3, half-maximal inhibitory concentration: 6070 nM
Compound 3: middle estimate off by 1.2-fold (0.08 log units), on the low side; the range from low to high includes it.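

Among these compounds, compound 3 gives the first readable step at this place, an amine nitrogen whose other neighbour is an amide-type nitrogen: in this assay, putting (2-chlorophenyl)carbonyl in place of 2-chlorophenyl gives a 2.7-fold higher number from compound 1 to compound 3 (0.43 log units; beyond the scatter). The added carbonyl therefore weakens inhibition modestly without abolishing it, as compound 3 still has a measured value and not a limit. Nothing shown here explains why this change has that effect.

A single step cannot separate the effect of the carbonyl from that of the longer link to the chlorophenyl ring, and a methylene group in place of the carbonyl would be one way to test this. The role of the chlorine also remains open, as every compound shown carries it, so a plain benzoyl group on the same nitrogen would address a different question.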